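A Hydroxy Group Added to Compound 1

The source may report more compounds than this note shows. Statements on the series, on what has been measured and on what is new or still open speak of the compounds shown alone.

In a functional assay on HOP-62 cells (Homo sapiens) for inhibition, read by sulforhodamine B assay (on this read-out lower numbers stand for stronger inhibition of growth and higher numbers for weaker inhibition of growth), compound 1 `c1ccc(-c2ccc(-c3ccc(-c4nc5ccccc5[nH]4)cc3)cc2)cc1` gives 100000 nM. Among the measured compounds shown here, compound 3 `Clc1cccc(-c2ccc(-c3ccc(-c4nc5ccccc5[nH]4)cc3)cc2)c1` gives 100000 nM, so the two stand level at the highest number measured so far, while compound 2 `Oc1ccc(-c2ccc(-c3ccc(-c4nc5ccccc5[nH]4)cc3)cc2)cc1` gives 47200 nM. Compound 4 `Oc1cccc2[nH]c(-c3ccc(-c4ccc(-c5ccccc5)cc4)cc3)nc12` is unmeasured and differs from compound 1 in one place: hydroxy in place of hydrogen on an aromatic carbon. The closest guide is a 2.1-fold lower number from compound 1 to compound 2 (0.33 log units; beyond the scatter), a modest step with hydroxy in place of hydrogen elsewhere on the molecule. Chloro in place of hydrogen gave no change at the digits printed from compound 1 to compound 3 (within the scatter), which does not bear directly on a hydroxy group. For the measured compounds named here, with only one hydroxy precedent, a step of similar size is expected, estimated as a 2.1-fold lower number from compound 1 to compound 4 (0.32 log units; beyond the scatter). For compound 4 the expected value is 48000 nM, with an estimated range of 18000 nM to 100000 nM.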

Compound 4, concentration for 50% growth inhibition: 9040 nM
The estimate for compound 4 lay 5.3-fold (0.73 log units) above the measured number, outside the stated range (below it).
By their numbers in this assay, from the lowest: compound 4; then compound 2; then compounds 1 and 3 (each within the scatter of the next).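

In this assay, hydroxy in place of hydrogen on this aromatic carbon, ortho to a fused ring, gives an 11-fold lower number from compound 1 to compound 4 (1.04 log units; beyond the scatter). The same swap elsewhere on the molecule gave only a 2.1-fold lower number from compound 1 to compound 2 (0.33 log units; beyond the scatter), so in these two cases the size of the step depends on where the hydroxy group sits. Nothing measured here explains the larger step at this position. From the compounds shown here alone, whether an amine or a methoxy group on this same carbon would give a similar step remains open.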